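Methoxy for Ethoxycarbonyl in a Cytotoxicity Screen

The source may report more compounds than this note shows. Statements on the series, on what has been measured and on what is new or still open speak of the compounds shown alone.

Three compounds with a shared core have been checked in an ADME assay on HT-29 cells (Homo sapiens) for cytotoxicity, read by luminescence and CellTiter-Glo, with a stated time of 12 h; a lower number here means that less compound is tolerated, a higher number that more compound is tolerated. Compound 1 `O=C(Nc1nc2ccc(Oc3ccc(F)c(NC(=O)C4(c5cccc(C(F)(F)F)c5)CC4)c3)cc2s1)C1CC1` gives > 50000 nM, a limit of the assay rather than a number. Compound 2 `O=C(CCc1cccc(C(F)(F)F)c1)Nc1cc(Oc2ccc3nc(NC(=O)C4CC4)sc3c2)ccc1F` also gives > 50000 nM, again a limit. Compound 3 `CCOC(=O)c1cccc(NC(=O)Nc2cc(Oc3ccc4nc(NC(=O)C5CC5)sc4c3)ccc2F)c1` gives > 50000 nM, once more a limit, so compound 3 stands at the edge of what this assay can report, as the limit of > 50000 nM in this assay, at which 3 of the 3 values shown sit, shows. The step that the two limits leave unreadable from compound 2 to compound 3 therefore cannot be read. Compound 4 `COc1cccc(NC(=O)Nc2cc(Oc3ccc4nc(NC(=O)C5CC5)sc4c3)ccc2F)c1` differs from compound 3 by methoxy in place of ethoxycarbonyl on an aromatic carbon. Within the data shown here, no measured step bears on this change, and with every value at the limit, compound 4 is expected to sit there too, the step of a number no higher from compound 3 to compound 4 (the limit leaves the size open) being expected to show nothing beyond the scatter. Compound 4 is estimated at 50000 nM, between 20000 nM and 100000 nM.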

Compound 4, half-maximal cytotoxic concentration: > 50000 nM
Compound 4 was reported as a limit (the forecaster's own chance of this, stated with the estimate: 80%); the middle value sits exactly at the limit.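

Among these compounds, each result for compound 2, compound 3 and compound 4 is a limit rather than a number, so no step between them can be read. Whether methoxy and ethoxycarbonyl differ at all in this assay stays open, and so does the concentration at which any of these compounds turns cytotoxic.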